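Chain shortening on the ether-linked hydroxamate series

This account rests on a few compounds, and the source may have more. Where it says the series, first, only, none or still open, it means among the compounds named here.

Compound 2 `Cc1noc(C)c1-c1cc(OCCCCCC(=O)NO)cc(C(=O)c2ccccc2)c1` in an assay for binding affinity to histone acetyltransferase KAT2B (Homo sapiens), tested at 25 uM (a lower number here means that the compound stabilises the target less, a higher number that the compound stabilises the target more against heat), gives 0.28 degrees C and stands second highest of the three numbers: compound 1 `Cc1noc(C)c1-c1cc(OCCCCCCCC(=O)NO)cc(C(=O)c2ccccc2)c1` gives -0.31 degrees C, and compound 3 `Cc1noc(C)c1-c1cc(NC(=O)CCCCCCC(=O)NO)cc(C(=O)c2ccccc2)c1` gives 1.35 degrees C, which lies beyond the scatter above compound 2. Compound 4 `Cc1noc(C)c1-c1cc(OCCCCC(=O)NO)cc(C(=O)c2ccccc2)c1` carries the change (hydroxycarbamoyl in place of (hydroxycarbamoyl)methyl on a saturated chain carbon, four bonds along the chain from an oxygen on an aromatic ring). For the measured compounds named here, the only measured step of the same kind is a number 0.59 degrees C higher from compound 1 to compound 2 (within the scatter), a shortening of the same chain by two bonds that stayed within the scatter. Removing one further chain carbon is therefore expected to move this assay by nothing beyond the scatter, in either direction, with a number 0.12 degrees C higher from compound 2 to compound 4 (within the scatter) as the expected step. Compound 4 is estimated at 0.4 degrees C, within a range from -0.6 degrees C to 1.4 degrees C.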

Compound 4, shift of the target's melting temperature: -7.9 degrees C
The estimate for compound 4 lay 8.3 degrees C above the measured number, and the stated range ends above it.
By their numbers in this assay, from the lowest: compound 4; then compounds 1 and 2 (each within the scatter of the next); then compound 3.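

In the ether-linked series, removing one chain carbon at this place, four bonds along the chain from an oxygen on an aromatic ring, gives in this assay a number 8.2 degrees C lower from compound 2 to compound 4 (beyond the scatter), and the full shortening gives a number 7.6 degrees C lower from compound 1 to compound 4 (beyond the scatter). Among compound 1, compound 2 and compound 4, chain length therefore acts as a sharp break, not a gradual drift. No available data bear on the origin of this break.

On these data alone, it remains open whether a carboxylic acid in place of hydroxycarbamoyl at this chain length gives a similar number. As far as these compounds go, whether an even shorter chain continues the drop is also open.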